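The source may hold more compounds than are shown below. What is called first, only, known or untested is meant among the compounds shown, and "the series" means these compounds.

In a functional assay on SK-OV-3 cells (Homo sapiens) for antiproliferative activity, read by MTT assay, with a stated time of 24 h (on this read-out lower numbers stand for stronger inhibition and higher numbers for weaker inhibition), compound 1 `COc1ccc(C(=O)/C=C/c2ccc3ccccc3n2)c2c1C=CC(C)(C)O2` gives 2350 nM. Compound 2 `COc1ccc(/C=C/C(=O)c2ccc(OC)c3c2OC(C)(C)C=C3)cn1` reaches only a limit of the assay, > 10000 nM. Compound 2 thus sits at the limit of > 10000 nM in this assay, at which 1 of the 2 values shown sits, the weaker end of the two values shown. Compound 3 `COc1ccccc1/C=C/C(=O)c1ccc(OC)c2c1OC(C)(C)C=C2` carries 2-methoxyphenyl in place of 6-methoxypyridin-3-yl on a double-bonded chain carbon bound to a double-bonded chain carbon. For the measured compounds named here, no step between measured compounds is available, so the size of this change in this assay rests on no measured pair; a modest gain toward the value of compound 1 seems possible, though a step no larger than the scatter would not surprise. The expected step is an at least 1.2-fold lower number from compound 2 to compound 3 (0.09 log units; that floor lies within the scatter). For compound 3 the estimate in this assay is 8000 nM, with a range from 2500 nM to 30000 nM.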

Compound 3, half-maximal inhibitory concentration: > 10000 nM
Compound 3: a limit, no number; the forecaster's own chance of this, stated with the estimate: 40%; at least 1.2-fold (0.09 log units) between middle value and limit.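

Compound 3, like compound 2, gives a limit and not a number, so no step between them can be read: the limit of > 10000 nM in this assay, at which 2 of the 3 values shown sit.

Which of 2-methoxyphenyl and 6-methoxypyridin-3-yl gives the lower number in this assay stays open.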